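Adding One Methyl to the Highest of Three Numbers

The source may hold more compounds than are shown below. What is called first, only, known or untested is meant among the compounds shown, and "the series" means these compounds.

In an ADME assay on BHK-21 cells (Mesocricetus auratus) for cytotoxicity, read by MTT assay, with a stated time of 72 h (on this read-out lower numbers stand for higher toxicity in this test and higher numbers for lower toxicity in this test), compound 2 `NS(=O)(=O)c1ccc(N2N=C(c3ccc(OCc4ccccc4)cc3)CC2c2ccccc2)cc1` gives 80000 nM, the highest of three numbers, against compound 3 `NS(=O)(=O)c1ccc(N2N=C(c3ccc(Oc4ccccc4)cc3)CC2c2ccccc2)cc1` at 11000 nM and compound 1 `Cc1ccc(C2CC(c3ccccc3)=NN2c2ccc(S(N)(=O)=O)cc2)cc1` at 7000 nM. Compound 4 `Cc1cccc(C2CC(c3ccc(OCc4ccccc4)cc3)=NN2c2ccc(S(N)(=O)=O)cc2)c1` has methyl in place of hydrogen on an aromatic carbon, meta to a large group (methyl in place of hydrogen on an aromatic carbon). For the measured compounds named here, the one measured step, a 7.3-fold lower number from compound 2 to compound 3 (0.86 log units; beyond the scatter), is modest but swaps phenyl for benzyl on an oxygen on an aromatic ring, so it bears only loosely on this change. Compound 1 also carries a methyl, yet no measured partner lacks it. No step beyond the scatter is therefore expected, with a slight lean towards a lower number. The expected step runs a 1.6-fold lower number from compound 2 to compound 4 (0.20 log units; within the scatter). For compound 4 the estimated value is 50000 nM, with an expected range of 15000 nM to 120000 nM.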

Compound 4, half-maximal cytotoxic concentration: 8000 nM
Compound 4: the middle estimate sits 6.3-fold (0.80 log units) above what was measured; the measured number lies below the stated range.
By their numbers in this assay, from the lowest: compounds 1, 4 and 3 (each within the scatter of the next); then compound 2.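

In this assay, methyl in place of hydrogen on an aromatic carbon, the change of phenyl to 3-methylphenyl, gives a 10-fold lower number from compound 2 to compound 4 (1.00 log units; beyond the scatter), a step beyond the scatter. For the compounds shown here, this is the first measured pair for a methyl, and it shows that one added carbon at this position can move the number by more than the scatter. Nothing available gives a reason for the size of this step. The compounds shown leave open whether an amine, a methoxy group or a chlorine atom at this same place would move the number as far.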